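The source may report more compounds than this note shows. Statements on the series, on what has been measured and on what is new or still open speak of the compounds shown alone.

Working notes on the series.

Compound 1 `Cc1ccc(C2C(C#N)=C(N)N(c3ccc(S(N)(=O)=O)cc3)C3=C2C(=O)CCC3)cc1` is the starting point of this step. Within the data shown here, in a functional assay on Ehrlich cells (Mus musculus) for antiproliferative activity, read by trypan blue exclusion, with a stated time of 2 h, tested at 50 ug/mL (on this read-out higher numbers stand for a stronger effect at the one concentration tested and lower numbers for a weaker effect), compound 1 gives 50%, which places it at the lower of the two numbers so far measured. Compound 2 `N#CC1=C(N)N(c2ccc(S(N)(=O)=O)cc2)C2=C(C(=O)CCC2)C1c1ccc(O)cc1` is its nearest neighbour: in this assay compound 2 gives 100%. Among the measured compounds shown here, the one measured step between them, a number 50 percentage points higher from compound 1 to compound 2 (beyond the scatter), is the only comparison available, and it concerns a change on the aromatic carbon of the pendant ring, not an exchange of that ring as a whole.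

The compound to be measured is compound 3 `N#CC1=C(N)N(c2ccc(S(N)(=O)=O)cc2)C2=C(C(=O)CCC2)C1c1cccs1`. Compared with compound 1 the change is thiophen-2-yl in place of 4-methylphenyl on a saturated ring carbon. For the measured compounds named here, no measured step bears on this exchange directly; the step from compound 1 to compound 2 shows only that the read-out in this assay responds strongly to a change on this part of the core. The direction for compound 3 is therefore open, with a wide range on either side of compound 1 the only honest expectation.

The estimate for compound 3 in this assay is 65%, expected to lie between 30% and 100%. The step this estimate means is a number 15 percentage points higher from compound 1 to compound 3 (beyond the scatter), an expected shift that may fall anywhere within the scatter or beyond it.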

Compound 3, a percentage reported as activity, at one concentration (the size of the read-out at that concentration, not a potency): 88%
For compound 3 the middle estimate is 23 percentage points below the measured one; the measured number falls inside the stated range.
By their numbers in this assay, from the lowest: compound 1; then compound 3; then compound 2.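

The exchange of the whole pendant ring on this saturated ring carbon is itself a strong lever in this assay, with a number 38 percentage points higher from compound 1 to compound 3 (beyond the scatter), so a high read-out here is not tied to a six-membered aromatic ring of carbon only. The other comparison, a number 12 percentage points lower from compound 2 to compound 3 (beyond the scatter), shows that thiophen-2-yl recovers much of the read-out of compound 2 without any hydroxy group, although 4-hydroxyphenyl remains ahead of it by a modest margin beyond the scatter. The earlier step concerned only a change on the pendant ring, whereas these steps show that the ring itself can be replaced at this position, and that a high read-out can be reached with either a five-membered or a six-membered aromatic ring.

The compounds shown leave open whether the gain from thiophen-2-yl follows its sulfur or its smaller ring, a question that furan-2-yl or an unsubstituted phenyl ring at the same carbon would help to separate. No data given here explain why either step has the size it has.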